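Hydroxybenzyl series: the step to compound 3

This account rests on a few compounds, and the source may have more. Where it says the series, first, only, none or still open, it means among the compounds named here.

Measured in a functional assay on K562 cells (Homo sapiens) for cytotoxicity; a higher number here means a weaker inhibitor, a lower number a stronger inhibitor:
- compound 1 `CC(C)C(CO)Nc1nc(NCc2ccccc2O)c2ncn(C(C)C)c2n1`: 10900 nM
- compound 2 `CC(C)C(CO)Nc1nc(NCc2cccc(O)c2)c2ncn(C(C)C)c2n1`: 16100 nM

Compound 2 at 16100 nM stands level with compound 1 within the scatter, and only these two values are available so far. Compound 3 `CC(C)C(CO)Nc1nc(NCc2ccc(O)cc2)c2ncn(C(C)C)c2n1` carries 4-hydroxyphenyl in place of 3-hydroxyphenyl on a saturated chain carbon bound to a nitrogen on an aromatic ring and the rest of the structure is unchanged. Among the measured compounds shown here, one measured step bears on this, 3-hydroxyphenyl in place of 2-hydroxyphenyl at the same place, which is a 1.5-fold higher number from compound 1 to compound 2 (0.17 log units; within the scatter) and gives no sign of a large response to this kind of change. One step is thin evidence, so the range stays wide. The expected result in this assay is a 1.2-fold lower number from compound 2 to compound 3 (0.06 log units; within the scatter) and no step beyond the scatter is expected, in either direction. Compound 3 is expected at 14000 nM with an estimated range from 7000 nM to 28000 nM as its bounds.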

Compound 3, half-maximal inhibitory concentration: 14800 nM
For compound 3 the middle estimate is 1.1-fold (0.02 log units) below the measured one, and the stated range covers the measured number.
By their numbers in this assay, from the lowest: compounds 1, 3 and 2 (each within the scatter of the next).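

With 4-hydroxyphenyl in place, all three hydroxyphenyl groups at this position can now be compared in this assay: the new steps are a 1.1-fold lower number from compound 2 to compound 3 (0.04 log units; within the scatter) and a 1.4-fold higher number from compound 1 to compound 3 (0.13 log units; within the scatter). Neither step leaves the scatter, so on a saturated chain carbon bound to a nitrogen on an aromatic ring, the 2-hydroxyphenyl, 3-hydroxyphenyl and 4-hydroxyphenyl groups of compound 1, compound 2 and compound 3 cannot be told apart, a result that a single step could not give. Nothing available offers a reason for this flat response.

Still open, going by these compounds, is whether the hydroxyl group matters at all, which plain phenyl, methoxyphenyl or aminophenyl at this position would test. Also open, on these data alone, is whether a hydroxyphenethyl group in place of the hydroxybenzyl groups would move the number beyond the scatter.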